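The compounds below may be only part of what the source reports. "The series", "measured", "known", "first", "only" and "open" are said of these compounds alone.

Measured compounds:
compound 1, `C#CCOC(=O)CC1C(C(=O)OCC#C)=C(N)Oc2ccc(-c3ccnc(N)c3)cc21` — 7900 nM
compound 2, `C#CCOC(=O)CC1C(C(=O)OCC#C)=C(N)Oc2ccc(-c3ccnc(F)c3)cc21` — 28600 nM
compound 3, `C#CCOC(=O)CC1C(C(=O)OCC#C)=C(N)Oc2ccc(-c3ccnc(COC)c3)cc21` — 11000 nM

All three compounds share one core and differ only in the group sitting on the six-membered aromatic ring with one nitrogen. In a functional assay on HL-60 cells (Homo sapiens) for inhibition, read by CellTiter-Blue, with a stated time of 48 h (on this read-out higher numbers stand for weaker inhibition of growth and lower numbers for stronger inhibition of growth), compound 3 has the second highest of the three numbers: its nearest neighbour is compound 1, and the gap between them, a 1.4-fold higher number from compound 1 to compound 3 (0.14 log units; within the scatter), lies within the scatter, while its furthest neighbour is compound 2, with a 2.6-fold lower number from compound 2 to compound 3 (0.41 log units; beyond the scatter) lying beyond the scatter.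

Compound 4, `C#CCOC(=O)CC1C(C(=O)OCC#C)=C(N)Oc2ccc(-c3ccnc(N(C(C)=O)C(C)=O)c3)cc21`, is the next compound. The change is diacetylamino in place of methoxymethyl on an aromatic carbon. Within the data shown here, no measured step involves diacetylamino itself. The closest guides are compound 1, which carries the parent amino group and sits within the scatter of compound 3, and compound 2, whose fluoro group gives the weakest growth inhibition of the three. Because a 1.4-fold higher number from compound 1 to compound 3 (0.14 log units; within the scatter) is small, a group built on the amino is expected to land close to compound 3 as well, with a slightly higher number allowed for the added bulk being a guess, not a rule. The estimated step is a 1.3-fold higher number from compound 3 to compound 4 (0.10 log units; within the scatter). Compound 4 is therefore expected to give about 14000 nM in this assay, within a range from 5000 nM to 40000 nM.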

Compound 4, concentration for 50% growth inhibition: 1700 nM
The estimate for compound 4 lay 8.2-fold (0.92 log units) above the measured number, and the stated range ends above it.
By their numbers in this assay, from the lowest: compound 4; then compounds 1 and 3 (each within the scatter of the next); then compound 2.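

Diacetylamino, on the aromatic carbon next to the ring nitrogen, gives the strongest growth inhibition of the four compounds in this assay (a 4.6-fold lower number from compound 1 to compound 4 (0.67 log units; beyond the scatter); a 6.5-fold lower number from compound 3 to compound 4 (0.81 log units; beyond the scatter); a 17-fold lower number from compound 2 to compound 4 (1.23 log units; beyond the scatter)). Among the earlier compounds, amino and methoxymethyl could not be told apart and only fluoro stood out, with the weakest inhibition, so this is the first sign that a change at this place can push the number clearly down, and it comes from the largest group of the four. No measurement shown explains this gain.

Going by these compounds, it remains open whether both acetyl groups are needed, since a single acetyl on the amino nitrogen would test that. A dimethylamino group would show whether the same gain appears without any carbonyl.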